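The source may hold more compounds than are shown below. What is called first, only, known or untested is meant among the compounds shown, and "the series" means these compounds.

Measured in an ADME assay (liver) for metabolic stability, with Liver microsome (Homo sapiens) as the target, using microsomes; on this read-out lower numbers stand for a shorter-lived compound and higher numbers for a longer-lived compound:
Compound 1 (`CCCc1nc2ccccn2c1C(=O)NCc1ccc(-c2ccccc2)cc1`): 0.373 h
Compound 2 (`CCc1nc2ccc(Cl)cn2c1C(=O)NCc1ccc(-c2ccc(C)cc2)cc1`): 0.508 h
Compound 3 (`CCc1nc2cc(Cl)ccn2c1C(=O)NCc1ccc(-c2ccc(C(=O)O)cc2)cc1`): > 2 h (a limit, not a number)

Compound 3 stands only at a limit of the assay (the limit of > 2 h in this assay, at which 1 of the 3 values shown sits), and no number is known for it. Compound 4 (`CCc1nc2cc(Cl)ccn2c1C(=O)NCc1ccc(N2CCCCC2)cc1`) differs from compound 3 by one exchange (piperidin-1-yl in place of 4-carboxyphenyl on an aromatic carbon): piperidin-1-yl in place of 4-carboxyphenyl on an aromatic carbon. Among the compounds with values here, no measured pair shows this exchange alone. The two compounds without a 4-carboxyphenyl group, compound 1 (0.373 h) and compound 2 (0.508 h), both gave numbers. The step expected in this assay is therefore a large one toward a shorter life, an at least 5.0-fold lower number from compound 3 to compound 4 (0.69 log units; beyond the scatter) by this estimate. For compound 4 the expected half-life of 0.4 h (range 0.15 h to 1 h) is an estimate.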

Compound 4, half-life: 0.22 h
Compound 4: middle estimate off by 1.8-fold (0.26 log units), on the high side, within the range that was stated.
By their numbers in this assay, from the lowest: compounds 4, 1 and 2 (each within the scatter of the next, the first and the last beyond it). At a limit, above all of these: compound 3.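

In this assay, within the data shown here, piperidin-1-yl in place of 4-carboxyphenyl on an aromatic carbon, para to a large group, gives an at least 9.0-fold lower number from compound 3 to compound 4 (0.95 log units; beyond the scatter), the first step at this position that rests on a single exchange. Compound 1 and compound 2 each differ from compound 3 in more than one place and could not show this. The step has only a lower bound, since compound 3 stands at a limit and not at a number: the limit of > 2 h in this assay, at which 1 of the 4 values shown sits.

Whether the carboxylic acid alone accounts for the step stays open. As far as these compounds go, how a plain phenyl or a morpholine would read at this position on the core of compound 4 also stays open.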